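A few compounds are considered here, and "the series" means these few. Any claim that something is new, unique, unknown or untested is made for them only; others in the source may bear on it.

Three hydroxamic acids sharing one core were measured in an assay on Sf9 cells for inhibition of protein deacetylase HDAC6 (Homo sapiens), read by fluorescence, with a stated time of 40 min, tested at 100 nM; a higher number here means more inhibition at the concentration tested (going by the name of the read-out), a lower number less inhibition. Compound 1 `Cc1ccccc1-n1nc(-c2ccccc2)nc1CNc1ccc(C(=O)NO)cc1` gives 57.1%; compound 2 `O=C(NO)c1ccc(NCc2nc(-c3ccc(F)cc3)nn2-c2ccccc2)cc1` gives 70.9%; compound 3 `O=C(NO)c1ccc(NCc2nc(-c3ccsc3)nn2-c2ccccc2)cc1` gives 53.4%. Among these three numbers compound 1 stands second highest: its nearest neighbour is compound 3, lower by an amount within the scatter, while compound 2 lies higher by an amount beyond it.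

For the measured compounds named here, the only step available between two measured compounds that differ in one place is a number 17.5 percentage points lower from compound 2 to compound 3 (beyond the scatter), and that exchange sits on an aromatic carbon of the core, not on the aromatic nitrogen.

Compound 4 `CCc1ccc(-n2nc(-c3ccccc3)nc2CNc2ccc(C(=O)NO)cc2)cc1` has not yet been measured. It differs from compound 1 in one place: 4-ethylphenyl in place of 2-methylphenyl on an aromatic nitrogen. Going by the values given here, no measured pair shows what an exchange on that aromatic nitrogen does in this assay, so the measured step from compound 2 to compound 3 does not bear directly on it. With no evidence pointing either way, the expected step of a number 0.1 percentage points lower from compound 1 to compound 4 (within the scatter) is one not beyond the scatter. Compound 4 is therefore estimated at 57%, with a range from 40% to 72%.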

Compound 4, a percentage reported as inhibition, at one concentration (the size of the read-out at that concentration, not a potency): 38.3%
Compound 4: middle estimate off by 18.7 percentage points, on the high side; measured number outside the range, below it.
By their numbers in this assay, from the lowest: compound 4; then compounds 3 and 1 (each within the scatter of the next); then compound 2.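

The exchange of 2-methylphenyl for 4-ethylphenyl gives a number 18.8 percentage points lower from compound 1 to compound 4 (beyond the scatter) in this assay. For the compounds shown here, this is the first reading of any change on the aromatic nitrogen of the shared core, and it shows that the number responds to the group carried there, not only to the group on the aromatic carbon. Both groups are a single six-membered aromatic ring of carbon only, with no hydrogen-bond donors or acceptors and no net charge, so a step beyond the scatter appears here without any change in those counted features. Nothing at hand explains why the number falls with this exchange.

Because the alkyl chain and its place on the phenyl ring change together in this one step, the two compounds cannot say which of them goes with the lower number, and a 4-methylphenyl or a 2-ethylphenyl on the same nitrogen would separate the two. As far as these compounds go, how a phenyl bearing an amine or a carboxylic acid would behave at this position also stays open.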